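Compound 3 to compound 4: a new carbonyl-bound group

The compounds below may be only part of what the source reports. "The series", "measured", "known", "first", "only" and "open" are said of these compounds alone.

compound 1 `COc1ccc(-n2c(SCc3ccccc3)nnc2-c2cc(OC)c(OC)c(OC)c2)cc1`: 42400 nM
compound 2 `COc1ccc(C(=O)CSc2nnc(-c3cc(OC)c(OC)c(OC)c3)n2-c2ccc(OC)cc2)cc1`: > 60000 nM (a limit)
compound 3 `COc1ccc(-n2c(SCC(=O)c3ccc(F)cc3)nnc2-c2cc(OC)c(OC)c(OC)c2)cc1`: > 60000 nM (a limit)

All three entries come from a functional assay on HCT-116 cells (Homo sapiens) for inhibition, read by MTT assay, with a stated time of 48 h; a lower number here means a stronger inhibitor, a higher number a weaker inhibitor. Compound 3 gives only a limit, > 60000 nM. It sits at the limit of > 60000 nM in this assay, at which 2 of the 3 values shown sit, so no number fixes its place.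

Compound 4 `COc1ccc(-n2c(SCC(=O)c3ccc(OC)c(O)c3)nnc2-c2cc(OC)c(OC)c(OC)c2)cc1` differs from compound 3 by one change: 3-hydroxy-4-methoxyphenyl in place of 4-fluorophenyl on a carbonyl carbon. Going by the values given here, no measured compound carries the 3-hydroxy-4-methoxyphenyl group.

The nearest measured step, a step that the two limits leave unreadable from compound 2 to compound 3, concerns the same group on the carbonyl carbon but gives no size. The steps of an at least 1.4-fold higher number from compound 1 to compound 2 (0.15 log units; that floor lies within the scatter) and an at least 1.4-fold higher number from compound 1 to compound 3 (0.15 log units; that floor lies within the scatter) have floors within the scatter and fix no size either.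

Compound 1 gives 42400 nM, so a measurable number on the shared core is expected to be possible. A move toward a lower number is expected, though weakly supported. The expected step is an at least 3.0-fold lower number from compound 3 to compound 4 (0.47 log units; beyond the scatter). For compound 4 the estimate is 20000 nM, with an expected range from 1000 nM to 60000 nM.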

Compound 4, half-maximal inhibitory concentration: > 60000 nM
Compound 4: only a limit was reported (the forecaster's own chance of this, stated with the estimate: 40%); middle value at least 3.0-fold (0.47 log units) away from the limit.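

In this assay compound 4 gives > 60000 nM, which is a limit of the assay and not a number. Adding a hydroxy to the 4-methoxyphenyl of compound 2 therefore yields no measurable number, and three different phenyl groups on this carbonyl carbon now sit at the same limit: the limit of > 60000 nM in this assay, at which 3 of the 4 values shown sit. The only readable step, an at least 1.4-fold higher number from compound 1 to compound 4 (0.15 log units; that floor lies within the scatter), fixes no size, and the steps among the compounds at the limit cannot be read.

Going by these compounds alone, it remains open whether the carbonyl or the phenyl group attached to it governs the result, as the only number on the shared core belongs to compound 1, at 42400 nM. Also open, from the compounds shown here alone, is whether an amine or a carboxylic acid on the phenyl ring, or a longer chain on the sulfur, would give a number in this assay.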